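A few compounds are considered here, and "the series" means these few. Any claim that something is new, unique, unknown or untested is made for them only; others in the source may bear on it.

Of the compounds shown here, two sharing one core have been measured so far. In a functional assay on MCF7 cells (Homo sapiens) for cytotoxicity, read by MTT assay, with a stated time of 24 h (on this read-out lower numbers stand for stronger inhibition and higher numbers for weaker inhibition), compound 1 (`COc1ccc(/C=C2\CN(Cc3cn(Cc4ccc(F)cc4)nn3)C/C(=C\c3ccc(OC)cc3)C2=O)cc1`) gives > 100000 nM, which is a limit and not a number. In this assay compound 2 (`COc1ccc(/C=C2\CN(Cc3cn(Cc4ccccc4Cl)nn3)C/C(=C\c3ccc(OC)cc3)C2=O)cc1`) gives > 100000 nM, again a limit. Compound 2 therefore has no readable value and stands with compound 1 at the limit of > 100000 nM in this assay, at which 2 of the 2 values shown sit.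

Compound 3 (`COc1ccc(/C=C2\CN(Cc3cn(Cc4ccccc4F)nn3)C/C(=C\c3ccc(OC)cc3)C2=O)cc1`) departs from compound 2 in one place, fluoro in place of chloro on an aromatic carbon, ortho to a large group, so that 2-chlorobenzyl becomes 2-fluorobenzyl. For the measured compounds named here, the only measured step that bears on this is a step that the two limits leave unreadable from compound 1 to compound 2, with 2-chlorophenyl in place of 4-fluorophenyl, and it gives no size to carry over. No step beyond the scatter is therefore expected in this assay, and no direction can be assigned. The expectation rests on compound 2 at > 100000 nM, and another limit is the likeliest report. The expected step is a number no higher from compound 2 to compound 3 (the limit leaves the size open). The estimate for compound 3 is 100000 nM, with an expected range from 40000 nM to 300000 nM.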

Compound 3, half-maximal inhibitory concentration: >= 100000 nM
Compound 3 was reported as a limit (the forecaster's own chance of this, stated with the estimate: 75%); the middle value sits exactly at the limit.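

In this assay compound 3 gives >= 100000 nM, which is a limit and not a number. Compound 1 and compound 2 are also reported as limits, so no step among these compounds can be read. The compounds shown leave open how the groups on the shared core compare, since none has a readable value in this assay.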